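The source may report more compounds than this note shows. Statements on the series, on what has been measured and on what is new or still open speak of the compounds shown alone.

Compound 2, `COc1cc(CSc2cc(Cl)c(-c3nc(-c4ccccc4)no3)cc2S(=O)(=O)NC(=N)NO)cc(OC)c1OC`, gives 6610 nM in a functional assay on M14 cells (Homo sapiens); a higher number here means a weaker inhibitor of growth, a lower number a stronger inhibitor of growth. That is the highest of the three numbers recorded. Its nearest neighbour is compound 3, `N=C(NO)NS(=O)(=O)c1cc(-c2nc(-c3ccccc3)no2)c(Cl)cc1SCc1ccccc1`, which in this assay gives 2150 nM; the step of a 3.1-fold lower number from compound 2 to compound 3 (0.49 log units; beyond the scatter) corresponds to phenyl in place of 3,4,5-trimethoxyphenyl on a saturated chain carbon bound to a sulfur. Furthest from compound 2 is compound 1, `N=C(NO)NS(=O)(=O)c1cc(-c2nnc(-c3ccc(Cl)cc3)s2)c(Cl)cc1SCc1ccccc1`, which gives 1680 nM in this assay.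

The compound now in question is compound 4, `COc1cc(CSc2cc(Cl)c(-c3nc(-c4ccc(Cl)cc4)no3)cc2S(=O)(=O)NC(=N)NO)cc(OC)c1OC`. Relative to compound 2 the change is chloro in place of hydrogen on an aromatic carbon, para to a large group. Going by the values given here, no measured pair isolates exactly this change. The closest comparison is between compound 1, which carries the 4-chlorophenyl, and compound 3, which carries the unsubstituted phenyl; their two values in this assay lie within the scatter of each other, but the two compounds also differ in their five-membered ring, so the comparison is only indirect.

On this basis no step beyond the scatter is expected for compound 4 in this assay, and the estimated step is a 1.2-fold lower number from compound 2 to compound 4 (0.08 log units; within the scatter). Compound 4 is therefore expected to give about 5500 nM, with a likely range from 2500 nM to 12000 nM.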

Compound 4, concentration for 50% growth inhibition: 2190 nM
Estimate against measurement, compound 4: 2.5-fold (0.40 log units) above, outside the stated range (below it).
By their numbers in this assay, from the lowest: compounds 1, 3 and 4 (each within the scatter of the next); then compound 2.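

In this assay, going by these compounds alone, the change from phenyl to 4-chlorophenyl, standing alone in one pair of compounds, gives a 3.0-fold lower number from compound 2 to compound 4 (0.48 log units; beyond the scatter), so a single chloro at this position is enough to move the number beyond the scatter, whereas the earlier compounds offered only an indirect comparison that also involved a change in the five-membered ring. Compound 2 now has two single changes, at different places, that each lower the number: this one and a 3.1-fold lower number from compound 2 to compound 3 (0.49 log units; beyond the scatter). Nothing available here explains why the chloro has this effect.

What remains open is whether the chloro gives a similar step when phenyl stands in place of 3,4,5-trimethoxyphenyl on the chain carbon bound to the sulfur, since the compounds shown include no pair that tests the two changes together. As far as these compounds go, it is also open whether this step is particular to chloro or whether fluoro, methyl, methoxy or an amine on the same aromatic carbon would move the number in the same direction or to a similar extent.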